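The source may report more compounds than this note shows. Statements on the series, on what has been measured and on what is new or still open speak of the compounds shown alone.

Compound 1 has the structure `COCc1cccc(C[C@H](O)/C=C/[C@H]2CSC(=O)N2CCSCCCC(=O)O)c1`. In an assay on CHO cells for displacement of a labelled ligand from prostaglandin E2 receptor EP2 subtype (Mus musculus), read by scintillation counting, with a stated time of 60 min (on this read-out lower numbers stand for stronger inhibition and higher numbers for weaker inhibition), compound 1 gives only a limit of the assay, > 10000 nM. Compound 2 has the structure `O=C(O)CCCSCCN1C(=O)OC[C@@H]1/C=C/[C@@H](O)Cc1cccc(-c2ccccc2)c1`. In this assay compound 2 also gives only a limit, > 10000 nM. Compound 3 has the structure `O=C(O)CCCSCCN1C(=O)SC[C@@H]1/C=C/[C@@H](O)Cc1cccc(C(F)(F)F)c1`. In this assay compound 3 likewise gives only a limit, > 10000 nM.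

Compound 2 therefore stands at the limit of the assay, and every value shown sits there too, as the evidence records: the limit of > 10000 nM in this assay, at which 3 of the 3 values shown sit. Going by the values given here, the one step measured between compounds that differ in a single place, a step that the two limits leave unreadable from compound 1 to compound 3, cannot be read, since both ends are limits.

Compound 4, `O=C(O)CCCSCCN1C(=O)OC[C@@H]1/C=C/[C@@H](O)Cc1cccc(Cl)c1`, differs from compound 2 in one place: chloro in place of phenyl on an aromatic carbon. No measured step touches this change, and the only step shown is unreadable. There is thus no basis for expecting a readable move in this assay in either direction; what is expected is that compound 4 stays at the limit.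

The step from compound 2 to compound 4 is accordingly estimated as a step that the limit leaves unreadable from compound 2 to compound 4. Compound 4 is expected to give about 15000 nM, within a range from 5000 nM to 50000 nM.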

Compound 4, inhibition constant: > 10000 nM
Compound 4: only a limit was reported; the forecaster's own chance of this, stated with the estimate: 80%; the middle value does not contradict the limit.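

No new step can be read: in this assay compound 4 gives only a limit, > 10000 nM, and compound 2 also gives only a limit, so chloro in place of phenyl cannot be sized. The compounds shown leave open how the groups on the aromatic carbon rank against one another in this assay, as none of them gives a number: the limit of > 10000 nM in this assay, at which 4 of the 4 values shown sit.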